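A few compounds are considered here, and "the series" means these few. Any claim that something is new, unique, unknown or untested is made for them only; others in the source may bear on it.

Compound 3 `Nc1ncnc2c1nc(NCc1ccccc1Cl)n2[C@@H]1O[C@H](CO)[C@@H](O)[C@H]1O` gives 5700 nM in an assay on COS-7 cells for inhibition of sodium/nucleoside cotransporter 2 (Homo sapiens), read by scintillation counting, in the presence of a further agent that is not named here (a lower number here means a stronger inhibitor, a higher number a weaker inhibitor), the lowest of the two numbers shown, with compound 2 `Nc1ncnc2c1nc(NCCCc1ccccc1)n2[C@@H]1O[C@H](CO)[C@@H](O)[C@H]1O` giving 536000 nM in this assay. Compound 1 `CC(=O)OC[C@H]1O[C@@H](n2cnc3c(N)ncnc32)[C@H](O)[C@@H]1O` reaches only the limit of > 100000 nM in this assay. Compound 4 `Nc1ncnc2c1nc(NCc1ccccc1-c1ccccc1)n2[C@@H]1O[C@H](CO)[C@@H](O)[C@H]1O` differs from compound 3 by phenyl in place of chloro on an aromatic carbon. For the measured compounds named here, the only measured step, a 94-fold lower number from compound 2 to compound 3 (1.97 log units; beyond the scatter), concerns the chain rather than the group on the ring, so it bears on this change only loosely, and no measured step replaces chloro by phenyl. The expected step is therefore a 1.1-fold higher number from compound 3 to compound 4 (0.02 log units; within the scatter), within the scatter. Compound 4 is thus estimated to give 6000 nM in this assay, with a range from 1500 nM to 30000 nM.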

Compound 4, half-maximal inhibitory concentration: > 100000 nM
Compound 4: no number, only a limit; the forecaster's own chance of this, stated with the estimate: 5%; middle value at least 16-fold (1.22 log units) away from the limit.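

Phenyl in place of chloro on this aromatic carbon, ortho to a large group, gives an at least 17-fold higher number from compound 3 to compound 4 (1.24 log units; beyond the scatter) in this assay, the first measured step at the group on the ring rather than in the chain. The group at this place therefore matters strongly, and the two groups are not interchangeable here. Compound 4 gives only a limit, not a number: the limit of > 100000 nM in this assay, at which 2 of the 4 values shown sit.

As far as these compounds go, the full size of the step therefore stays open. So does what a methyl or methoxy group at this place would give, and whether the change from chloro to phenyl would read the same with another chain.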